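Aryl variation on the amine nitrogen: towards compound 4

The source may report more compounds than this note shows. Statements on the series, on what has been measured and on what is new or still open speak of the compounds shown alone.

Measured compounds in a functional assay on HeLa cells (Homo sapiens) for cytotoxicity, read by MTT assay, with a stated time of 48 h; on this read-out higher numbers stand for weaker inhibition and lower numbers for stronger inhibition:
Compound 1, `COc1ccc(N/C(CCNC2=CC(=O)c3ccccc3C2=O)=N\S(=O)(=O)c2ccc(C)cc2)cc1`, gives 7590 nM.
Compound 2, `Cc1ccc(S(=O)(=O)/N=C(/CCNC2=CC(=O)c3ccccc3C2=O)Nc2cccc(C)c2)cc1`, gives 9060 nM.
Compound 3, `Cc1ccc(S(=O)(=O)/N=C(/CCNC2=CC(=O)c3ccccc3C2=O)Nc2ccc(F)c(F)c2)cc1`, gives 8790 nM.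

All three share one core and differ only in the aryl group on the amine nitrogen. The steps among them are small: a 1.2-fold higher number from compound 1 to compound 2 (0.08 log units; within the scatter), a 1.2-fold higher number from compound 1 to compound 3 (0.06 log units; within the scatter) and a 1.0-fold lower number from compound 2 to compound 3 (0.01 log units; within the scatter) each fall within the scatter, so on the numbers shown compound 3 cannot be told apart from compound 1 or compound 2, and no one of the three stands out.

Compound 4, `Cc1ccc(S(=O)(=O)/N=C(/CCNC2=CC(=O)c3ccccc3C2=O)Nc2ccc(Cl)cc2Cl)cc1`, has not yet been measured in this assay. Its difference from compound 3 is 2,4-dichlorophenyl in place of 3,4-difluorophenyl on an amine nitrogen. The measured steps that bear on it are the three aryl swaps on the same nitrogen, and every one of them stayed within the scatter. The same kind of change, a halogenated phenyl in place of another halogenated phenyl, is therefore expected to give no step beyond the scatter in this assay, in either direction, so a 1.0-fold lower number from compound 3 to compound 4 (0.01 log units; within the scatter) is the estimated step. For compound 4 the estimate is 8500 nM, with a range from 4000 nM to 18000 nM.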

Compound 4, half-maximal inhibitory concentration: 20500 nM
The estimate for compound 4 lay 2.4-fold (0.38 log units) below the measured number; measured number outside the range, above it.
By their numbers in this assay, from the lowest: compounds 1, 3 and 2 (each within the scatter of the next); then compound 4.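

In this assay the aryl group on the amine nitrogen is no longer silent: 2,4-dichlorophenyl gives a 2.3-fold higher number from compound 3 to compound 4 (0.37 log units; beyond the scatter) and a 2.3-fold higher number from compound 2 to compound 4 (0.35 log units; beyond the scatter) and also a 2.7-fold higher number from compound 1 to compound 4 (0.43 log units; beyond the scatter) in the swaps from the three earlier aryl groups. Compound 1, compound 2 and compound 3 remain within the scatter of one another, so this position does respond to the aryl group, but the only response shown is towards weaker inhibition, and it comes from one replacement, in compound 4. A swap of one dihalogenated phenyl for another, with the same count of heavy atoms and no added donors or acceptors, is enough to produce this step, although nothing measured here shows what lies behind it.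

The swap from 3,4-difluorophenyl to 2,4-dichlorophenyl changes the halogen and the substitution pattern together, and the compounds shown cannot separate the two; 3,4-dichlorophenyl and 2,4-difluorophenyl on the same nitrogen would do so. Also open, from the compounds shown here alone, is whether any group here, such as a pyridyl ring or a phenyl carrying a carboxylic acid, could move the number below the level of compound 1, compound 2 and compound 3.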